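Replacing the morpholinyl carbonyl group of compound 3

The source may report more compounds than this note shows. Statements on the series, on what has been measured and on what is new or still open speak of the compounds shown alone.

Compound 1 `COc1cc(N2CCN(C(=O)C3CCC(O)CC3)CC2)ccc1Nc1nc(NC2CCCCC2)c2nc[nH]c2n1`: 15 nM
Compound 2 `COc1cc(N2CCN(C(=O)N3CCC(O)C3)CC2)ccc1Nc1nc(NC2CCCCC2)c2nc[nH]c2n1`: 27 nM
Compound 3 `COc1cc(N2CCC(C(=O)N3CCOCC3)CC2)ccc1Nc1nc(NC2CCCCC2)c2nc[nH]c2n1`: 50 nM

All three compounds were tested in a functional assay on HCT-116 cells (Homo sapiens) for cytotoxicity; a lower number here means a stronger inhibitor, a higher number a weaker inhibitor. Compound 3 gives the highest number of the three (50 nM). Its gap to compound 1 lies beyond the scatter, and its gap to compound 2 lies within it.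

Compound 4 `COc1cc(N2CCC(CC(=O)N3CCN(C)CC3)CC2)ccc1Nc1nc(NC2CCCCC2)c2nc[nH]c2n1` has not yet been measured. In it, ((4-methylpiperazin-1-yl)carbonyl)methyl stands in place of (morpholin-4-yl)carbonyl on a saturated ring carbon of the six-membered non-aromatic ring with 1 nitrogen: ((4-methylpiperazin-1-yl)carbonyl)methyl in place of (morpholin-4-yl)carbonyl on a saturated ring carbon.

Within the data shown here, only one measured step bears on this change, and only loosely. It is a 1.8-fold higher number from compound 1 to compound 2 (0.26 log units; within the scatter), which exchanges the group on a carbonyl carbon and stays within the scatter. Among the measured compounds shown here, that step is a different exchange, and no measured compound carries the entering group, so the data give no firm direction. No step beyond the scatter is therefore expected in this assay. The expected change is a 1.3-fold lower number from compound 3 to compound 4 (0.10 log units; within the scatter). For compound 4 the estimated value is 40 nM, with an expected range from 13 nM to 120 nM.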

Compound 4, half-maximal inhibitory concentration: 51 nM
The estimate for compound 4 lay 1.3-fold (0.11 log units) below the measured number; low and high end bracket the measured number.
By their numbers in this assay, from the lowest: compounds 1, 2, 3 and 4 (each within the scatter of the next, the first and the last beyond it).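

In this assay, putting ((4-methylpiperazin-1-yl)carbonyl)methyl in place of (morpholin-4-yl)carbonyl on a saturated ring carbon gives a 1.0-fold higher number from compound 3 to compound 4 (0.01 log units; within the scatter). The earlier compounds shown here offered no step at this position, and this one shows that the number stays within the scatter when a group of 10 heavy atoms, with 2 nitrogen and 1 oxygen, replaces a group of 8 heavy atoms, with 1 nitrogen and 2 oxygen. The data offer no measured property that would account for this result.

The step changes both the ring at the end of the group and the way its carbonyl is joined to the saturated ring carbon, so the two changes cannot be told apart here; ((morpholin-4-yl)carbonyl)methyl or (4-methylpiperazin-1-yl)carbonyl at this place would separate them. As far as these compounds go, it also remains open how this assay would respond to a group of a different kind on this carbon, such as a carboxylic acid, a primary amine or a longer chain ahead of the carbonyl.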